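Notes on a pyridin-2-yl variant of compound 1

This account rests on a few compounds, and the source may have more. Where it says the series, first, only, none or still open, it means among the compounds named here.

Measured so far:
- compound 1 `CCNC(=O)c1c(-c2ccccc2)c([C@H](C)Nc2ncnc(N)c2C#N)nc2ccc(F)cc12`: in an assay on Sf9 cells for inhibition of phosphatidylinositol 4,5-bisphosphate 3-kinase catalytic subunit beta isoform (Homo sapiens), with a stated time of 20 min (on this read-out higher numbers stand for weaker inhibition and lower numbers for stronger inhibition), compound 1 gives 17000 nM
- compound 2 `C[C@H](Nc1ncnc(N)c1C#N)c1nc2ccc(F)cc2c(C(=O)N2CC(O)C2)c1-c1ccccc1`: in this assay compound 2 gives 2720 nM

Compound 1 stands at the highest of the two numbers in this assay; the nearest is compound 2, reached by a 6.3-fold lower number from compound 1 to compound 2 (0.80 log units; beyond the scatter). That step changes the group on the carbonyl carbon only and says nothing about the aromatic substituent that is varied here.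

Compound 3 `CCNC(=O)c1c(-c2ccccn2)c([C@H](C)Nc2ncnc(N)c2C#N)nc2ccc(F)cc12` differs from compound 1 in one place: pyridin-2-yl in place of phenyl on an aromatic carbon. For the measured compounds named here, no measured pair touches this position, so there is no step of known size to lean on. With nothing to suggest either direction, the working expectation is that compound 3 will sit close to compound 1 in this assay, the expected step being a 1.1-fold lower number from compound 1 to compound 3 (0.05 log units; within the scatter), which is not beyond the scatter. The estimate for compound 3 is therefore 15000 nM, with a range of 5000 nM to 45000 nM, the width reflecting the absence of any precedent for this change.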

Compound 3, half-maximal inhibitory concentration: 11000 nM
Compound 3: middle estimate off by 1.4-fold (0.13 log units), on the high side; the measured number falls inside the stated range.
By their numbers in this assay, from the lowest: compound 2; then compounds 3 and 1 (each within the scatter of the next).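

This position now has its first measured step: in this assay, pyridin-2-yl in place of phenyl, on the aromatic carbon ortho to the ethylcarbamoyl group, gives a 1.5-fold lower number from compound 1 to compound 3 (0.19 log units; within the scatter). The swap keeps the count of heavy atoms and adds a ring nitrogen and one hydrogen-bond acceptor, yet compound 1 and compound 3 cannot be told apart in this read-out, so this single change shows no effect that can be separated from the scatter. No measurement is available that would explain the size of this step.

From the compounds shown here alone, it remains open whether the position tolerates change more generally, since pyridin-3-yl, pyridin-4-yl, a fluorophenyl or a small alkyl group such as methyl could behave differently from the two rings compared here. Going by these compounds, it is also open whether pyridin-2-yl would behave the same way alongside the 3-hydroxyazetidin-1-yl group on the carbonyl carbon, the change that gives a 6.3-fold lower number from compound 1 to compound 2 (0.80 log units; beyond the scatter).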